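Swapping a trifluoromethyl for a fluorophenyl ring

The compounds below may be only part of what the source reports. "The series", "measured", "known", "first", "only" and "open" are said of these compounds alone.

Compound 1 `Cc1n[nH]c(C(=O)O)c1Cc1cccc(-c2ccc(OC(F)(F)F)cc2)c1` and compound 2 `Cc1n[nH]c(C(=O)O)c1Cc1ccc(C(F)(F)F)cc1` share a core and differ in the group carried on the pendant benzene. In an assay on isolated protein for inhibition of 2-Hydroxyacid oxidase 2 (Homo sapiens), tested at 10 uM (a higher number here means a stronger effect of the compound at the concentration tested, a lower number a weaker effect), compound 1 gives 34%, while compound 2 gives 12%, the lower of the two numbers, and the gap between them lies beyond the usual scatter. Compound 3 `Cc1n[nH]c(C(=O)O)c1Cc1ccc(-c2ccc(F)cc2)cc1` has not yet been measured. Compared with compound 2, the change is 4-fluorophenyl in place of trifluoromethyl on an aromatic carbon. Among the compounds with values here, no measured pair shows this exact exchange, so its effect can only be estimated. Compound 1 carries a two-ring group and gives 34% in this assay, above compound 2. An upward step of a number 13 percentage points higher from compound 2 to compound 3 (beyond the scatter) is therefore expected for compound 3, though a result within the scatter would not surprise. Compound 3 is estimated at 25%, with a range from 5% to 50%.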

Compound 3, a percentage reported as inhibition, at one concentration (the size of the read-out at that concentration, not a potency): 25%
Estimate against measurement, compound 3: no gap at the digits printed; low and high end bracket the measured number.
By their numbers in this assay, from the lowest: compound 2; then compounds 3 and 1 (each within the scatter of the next).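

At the spot para to a large group on the pendant benzene, 4-fluorophenyl in place of trifluoromethyl gives a number 13 percentage points higher from compound 2 to compound 3 (beyond the scatter) in this assay. Within the data shown here, this is the first direct one-place comparison, and it shows that this position tolerates a second aromatic ring and that the read-out at the tested concentration improves modestly with it, although this is not a measure of potency. No measurement shown here explains why the number rises.

As far as these compounds go, it remains open whether the outer ring alone accounts for the step or whether its fluorine contributes, which a plain phenyl ring at the same place would test. Equally open, from the compounds shown here alone, is how this position would respond to an outer ring carrying an amine or a carboxylic acid.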